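A few compounds are considered here, and "the series" means these few. Any claim that something is new, unique, unknown or untested is made for them only; others in the source may bear on it.

Measured so far in an assay on Sf9 cells for inhibition of inhibitor of nuclear factor kappa-B kinase subunit epsilon (Homo sapiens), read by ADP-Glo, with a stated time of 60 min; on this read-out lower numbers stand for stronger inhibition and higher numbers for weaker inhibition:
Compound 1 `Cc1cccc(-c2c(N)n[nH]c2C)c1` gives > 100000 nM, which is a limit of this assay.
Compound 2 `Cc1[nH]nc(N)c1-c1cccc(C(F)(F)F)c1` gives > 100000 nM, again a limit.
Compound 3 `CC(=O)n1nc(C)c(-c2ccc(Cl)c(Cl)c2)c1N` gives > 100000 nM, also a limit.

Among the measured compounds shown here, the one step among the measured compounds, a step that the two limits leave unreadable from compound 1 to compound 2, cannot be read; the evidence is summed up as the limit of > 100000 nM in this assay, at which 3 of the 3 values shown sit. Compound 3 therefore stands where all three measured compounds stand, at the limit, with no ordering among them possible.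

Compound 4 `Cc1nn(C(=O)c2ccccc2)c(N)c1-c1ccc(Cl)c(Cl)c1` differs from compound 3 by phenyl in place of methyl on a carbonyl carbon. For the measured compounds named here, no measured step covers a change of this kind, so nothing beyond the shared limit informs the expectation. Compound 4 is therefore expected to remain at or near the limit, with an estimate of 100000 nM (range 30000 nM to 300000 nM). The step of a number no higher from compound 3 to compound 4 (the limit leaves the size open) is expected to be none beyond the scatter.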

Compound 4, half-maximal inhibitory concentration: > 100000 nM
Compound 4: only a limit was reported; the forecaster's own chance of this, stated with the estimate: 80%; the middle value lies on the limit itself.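

The step from compound 3 to compound 4 cannot be read, as each result in this assay is only a limit. The compounds shown leave open how they rank against one another and which change would give a readable value, with everything so far resting on one point: the limit of > 100000 nM in this assay, at which 4 of the 4 values shown sit.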